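A few compounds are considered here, and "the series" means these few. Any claim that something is new, unique, unknown or untested is made for them only; others in the source may bear on it.

Working notes on the series. Compound 1 `CC(C)(C)C#Cc1cc(N(C(=O)[C@H]2CC[C@H](C)CC2)[C@H]2CC[C@H](Oc3ccccn3)CC2)c(C(=O)O)s1`, compound 2 `CC(C)(C)C#Cc1cc(N(C(=O)[C@H]2CC[C@H](C)CC2)[C@H]2CC[C@@](O)(CO[C@H]3CCOC3)CC2)c(C(=O)O)s1` and compound 3 `CC(C)(C)C#Cc1cc(N(C(=O)[C@H]2CC[C@H](C)CC2)[C@H]2CC[C@H](Oc3nccs3)CC2)c(C(=O)O)s1` share one core and differ from one another in a single substituent. In an ADME assay on MT4 cells (Homo sapiens) for cytotoxicity, with a stated time of 5 days (a lower number here means that less compound is tolerated, a higher number that more compound is tolerated), compound 1 gives only a limit of the assay, > 20000 nM. In this assay compound 2 likewise gives only a limit, > 20000 nM. In this assay compound 3 also gives only a limit, > 20000 nM. Compound 3 therefore stands where every measured member of the series stands: at the limit, with no number that would rank it against the other two. Among the compounds with values here, the one measured exchange, a step that the two limits leave unreadable from compound 1 to compound 3, cannot be read in size because of the limit of > 20000 nM in this assay, at which 3 of the 3 values shown sit.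

Compound 4 `CC(C)(C)C#Cc1cc(N(C(=O)[C@H]2CC[C@H](C)CC2)[C@H]2CC[C@H](OC3COC3)CC2)c(C(=O)O)s1` has not yet been measured in this assay. Its difference from compound 3: oxetan-3-yl in place of 1,3-thiazol-2-yl on an oxygen on a saturated carbon. Within the data shown here, no measured step bears directly on this exchange, and the only step available in this region of the molecule, a step that the two limits leave unreadable from compound 1 to compound 3, is itself unreadable. Among the measured compounds shown here, nothing among the measured compounds shows any change at this substituent moving the read-out off the limit, so no step beyond the scatter is expected; the expected step is a step that the limit leaves unreadable from compound 3 to compound 4. Compound 4 is accordingly estimated at 30000 nM, with a range of 15000 nM to 80000 nM, and most probably it will again be reported only as a limit.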

Compound 4, half-maximal cytotoxic concentration: > 20000 nM
Compound 4 gave a limit, no number; the forecaster's own chance of this, stated with the estimate: 85%; the middle value is on the limit's open side.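

No new step can be read: the exchanges leading to compound 4 from compound 3 and from compound 1 cannot be sized in this assay, because every result is a limit: the limit of > 20000 nM in this assay, at which 4 of the 4 values shown sit.

The compounds shown leave open whether any change to the shared core gives a measured half-maximal cytotoxic concentration rather than a limit in this assay.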